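Aryl swap on the shared core: compound 3

This account rests on a few compounds, and the source may have more. Where it says the series, first, only, none or still open, it means among the compounds named here.

Among the compounds with values here, compound 1 `COc1cc(-c2ccnc3cc(-c4ccc(Cl)cc4)nn23)cc(OC)c1OC` gives 1490 nM in a functional assay on HeLa cells (Homo sapiens) for inhibition, read by CCK-8 assay, with a stated time of 48 h (a higher number here means a weaker inhibitor, a lower number a stronger inhibitor), the highest of the two numbers so far. Compound 2 `COc1ccc(-c2cc3nccc(-c4cc(OC)c(OC)c(OC)c4)n3n2)cc1F` gives 236 nM in this assay, and the step of a 6.3-fold lower number from compound 1 to compound 2 (0.80 log units; beyond the scatter) is the only measured one. Compound 3 `COc1ccc(-c2cc3nccc(-c4cc(OC)c(OC)c(OC)c4)n3n2)cc1N` differs from compound 1 as follows: 3-amino-4-methoxyphenyl in place of 4-chlorophenyl on an aromatic carbon. This change resembles the one measured in a 6.3-fold lower number from compound 1 to compound 2 (0.80 log units; beyond the scatter), where 3-fluoro-4-methoxyphenyl replaced 4-chlorophenyl, so a step of similar direction and roughly similar size is expected in this assay. Compound 3 is therefore estimated at 320 nM (range 80 nM to 1300 nM), an expected step of a 4.7-fold lower number from compound 1 to compound 3 (0.67 log units; beyond the scatter).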

Compound 3, half-maximal inhibitory concentration: 283 nM
For compound 3 the middle estimate is 1.1-fold (0.05 log units) above the measured one; low and high end bracket the measured number.
By their numbers in this assay, from the lowest: compounds 2 and 3 (each within the scatter of the next); then compound 1.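

In this assay the step at this aromatic carbon does not depend on fluoro: 3-amino-4-methoxyphenyl in place of 4-chlorophenyl gives a 5.3-fold lower number from compound 1 to compound 3 (0.72 log units; beyond the scatter) as well. Amino in place of fluoro gives a 1.2-fold higher number from compound 2 to compound 3 (0.08 log units; within the scatter) and so does not separate the two groups, even with the hydrogen-bond donor that amino adds. No measurement bears on the reason for either step.

Still open, from the compounds shown here alone, is how much of these steps belongs to the methoxy group, which a plain 3-aminophenyl would test. Also open, going by these compounds, is how hydroxyl or an acetamide would compare with amino on this ring.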